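From bromo to nitro on a shared core

A few compounds are considered here, and "the series" means these few. Any claim that something is new, unique, unknown or untested is made for them only; others in the source may bear on it.

Measured in a functional assay on HUVEC cells (Homo sapiens) for inhibition, with a stated time of 4 days; a lower number here means a stronger inhibitor, a higher number a weaker inhibitor 
Compound 1 `COc1ccc(C(N)=O)cc1COc1ccc(Cl)cc1` gives 660 nM 
Compound 2 `COc1ccc(C(N)=O)cc1/C=C/c1ccc(Br)cc1` gives 560 nM 

Compound 2 at 560 nM stands level with compound 1 at 660 nM, as the two values lie within the usual scatter of each other. Compound 3 `COc1ccc(C(N)=O)cc1/C=C/c1ccc([N+](=O)[O-])cc1` has not yet been measured. It carries nitro in place of bromo on an aromatic carbon, para to a large group (nitro in place of bromo on an aromatic carbon). Among the compounds with values here, compound 1 and compound 2 differ in more than one place, so no measured step shows what this exchange does in this assay. The expectation therefore starts from compound 2 at 560 nM, the closest measured relative. A modest move towards a higher number, meaning a somewhat weaker inhibitor, is expected, and it may not exceed the scatter. The expected change is a 1.4-fold higher number from compound 2 to compound 3 (0.15 log units; within the scatter) in this estimate. For compound 3 the estimated value is 800 nM, with an expected range from 250 nM to 2800 nM in this assay.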

Compound 3, half-maximal inhibitory concentration: 4700 nM
Compound 3: the middle estimate sits 5.9-fold (0.77 log units) below what was measured, and the stated range ends below it.
By their numbers in this assay, from the lowest: compounds 2 and 1 (each within the scatter of the next); then compound 3.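

Within the data shown here, putting nitro in place of bromo gives an 8.4-fold higher number from compound 2 to compound 3 (0.92 log units; beyond the scatter) in this assay and is the first single change here that can be read, since compound 1 and compound 2 differ in more than one place. It shows that this position, on an aromatic carbon para to a large group, is sensitive to what sits there: with the rest of the molecule unchanged, this one exchange leaves a clearly weaker inhibitor. No measurement shown here explains the loss.

From the compounds shown here alone, with only bromo and nitro compared at this position, it remains open whether the loss is particular to nitro or would also appear with other groups. An amine, a nitrile or a carboxylic acid in the same place would help to separate these possibilities, and hydrogen there would give a baseline for the shared core.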